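Cytotoxicity notes: sulfonylamidine naphthoquinone series, amine substituent

The source may report more compounds than this note shows. Statements on the series, on what has been measured and on what is new or still open speak of the compounds shown alone.

Measured compounds:
- compound 1 `Cc1ccc(S(=O)(=O)/N=C(/CCNC2=CC(=O)c3ccccc3C2=O)Nc2cccc(C(F)(F)F)c2)cc1`: 91500 nM
- compound 2 `Cc1ccc(S(=O)(=O)/N=C(/CCNC2=CC(=O)c3ccccc3C2=O)Nc2ccc(F)c(F)c2)cc1`: 55200 nM
- compound 3 `COc1cc(N/C(CCNC2=CC(=O)c3ccccc3C2=O)=N\S(=O)(=O)c2ccc(C)cc2)cc(OC)c1OC`: 75800 nM

In an ADME assay on HEK293 cells (Homo sapiens) for cytotoxicity, read by MTT assay, with a stated time of 48 h (a higher number here means a weaker inhibitor, a lower number a stronger inhibitor), compound 3 gives 75800 nM; compound 1 gives 91500 nM and compound 2 gives 55200 nM, and all three lie within the scatter of one another, as a 1.7-fold lower number from compound 1 to compound 2 (0.22 log units; within the scatter), a 1.2-fold lower number from compound 1 to compound 3 (0.08 log units; within the scatter) and a 1.4-fold higher number from compound 2 to compound 3 (0.14 log units; within the scatter) show. Compound 4 `Cc1ccc(S(=O)(=O)/N=C(/CCNC2=CC(=O)c3ccccc3C2=O)NC(C)C)cc1` differs from compound 3 by isopropyl in place of 3,4,5-trimethoxyphenyl on an amine nitrogen. For the measured compounds named here, none of the measured steps covers an exchange of an aryl group for an alkyl group on this nitrogen; the three aryl-to-aryl swaps all stayed within the scatter. The expectation is therefore no step beyond the scatter, a 1.0-fold lower number from compound 3 to compound 4 (0.00 log units; within the scatter). Compound 4 is estimated at 75000 nM, with a range from 30000 nM to 190000 nM.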

Compound 4, half-maximal inhibitory concentration: 71600 nM
For compound 4 the middle estimate is 1.0-fold (0.02 log units) above the measured one, within the range that was stated.
By their numbers in this assay, from the lowest: compounds 2, 4, 3 and 1 (each within the scatter of the next).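

In this assay, the amine nitrogen now carries an alkyl group, and the swap of an aryl group for isopropyl stays within the scatter against all three aryl compounds: a 1.1-fold lower number from compound 3 to compound 4 (0.02 log units; within the scatter), a 1.3-fold higher number from compound 2 to compound 4 (0.11 log units; within the scatter) and a 1.3-fold lower number from compound 1 to compound 4 (0.11 log units; within the scatter). With 12 heavy atoms and an aromatic ring leaving and 3 heavy atoms entering, the number stays in the same range, so this position tolerates both aryl and small alkyl groups in this assay. No measurement at hand explains this flat response.

Going by these compounds, whether a longer chain, an amine or a carboxylic acid on this nitrogen would stay in that range remains open. Also open, on these data alone, is how the number responds to changes elsewhere in the shared core.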